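Swapping a Phenyl Hydroxamate for an Ethenyl Hydroxamate

The source may hold more compounds than are shown below. What is called first, only, known or untested is meant among the compounds shown, and "the series" means these compounds.

Compound 1 `O=C(NO)c1ccc(-c2cn([C@@H]3C[C@@H](C(=O)O)N(Cc4ccccc4)C3)nn2)cc1` and compound 2 `O=C(/C=C/c1cn([C@@H]2C[C@@H](C(=O)O)N(Cc3ccccc3)C2)nn1)NO` share one core and differ in a single change, (2-(hydroxycarbamoyl)ethenyl in place of 4-(hydroxycarbamoyl)phenyl on an aromatic carbon). In an assay on Sf9 cells for inhibition of histone deacetylase 11 (Homo sapiens), read by fluorescence, tested at 0.5 uM (a lower number here means less inhibition, a higher number more inhibition at the concentration tested (going by the name of the read-out)), compound 1 gives < 10%, which is a limit of the assay and not a number. In this assay compound 2 gives 12%. The measured step is a number at least 2 percentage points higher from compound 1 to compound 2 (that floor lies within the scatter); its size is known only as a floor because of the limit of < 10% in this assay, at which 2 of the 3 values shown sit. Compound 3 `O=C(NO)c1ccc(-c2cn([C@H]3C[C@@H](CO)N(CCCc4ccccc4)C3)nn2)cc1` carries another core, and how it differs from the core of compound 1 is not broken down here. In this assay compound 3 gives < 10%, a limit of the assay. Compound 4 `O=C(/C=C/c1cn([C@H]2C[C@@H](CO)N(CCCc3ccccc3)C2)nn1)NO` arises from compound 3 by the same kind of change, (2-(hydroxycarbamoyl)ethenyl in place of 4-(hydroxycarbamoyl)phenyl on an aromatic carbon), at a place described in the same words. For compound 4 a step of a number no lower from compound 3 to compound 4 (the limit leaves the size open) is expected in this assay, resting on a number at least 2 percentage points higher from compound 1 to compound 2 (that floor lies within the scatter). Compound 4 is therefore estimated at 10%, between 3% and 20%.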

Compound 4, a percentage reported as inhibition, at one concentration (the size of the read-out at that concentration, not a potency): 31%
The estimate for compound 4 lay 21 percentage points below the measured number, and the stated range ends below it.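

In this assay, putting 2-(hydroxycarbamoyl)ethenyl in place of 4-(hydroxycarbamoyl)phenyl gives a number at least 21 percentage points higher from compound 3 to compound 4 (beyond the scatter). Set beside the earlier case, the change has now been seen on two cores, but the two steps cannot be ranked: the same change on two cores in this assay, a number at least 2 percentage points higher (that floor lies within the scatter) from compound 1 to compound 2 and a number at least 21 percentage points higher (beyond the scatter) from compound 3 to compound 4; the limit leaves it open whether they differ The change thus gives a rise beyond the scatter on the core of compound 3, whereas on the core of compound 1 no such rise is shown, and it remains unknown whether the core affects the size of the step.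

The compounds shown leave open which of the differences between the two cores goes with the higher number. Going by these compounds, whether a longer chain ending in hydroxycarbamoyl would behave like the ethenyl group also remains open.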